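This account rests on a few compounds, and the source may have more. Where it says the series, first, only, none or still open, it means among the compounds named here.

Results in an ADME assay for permeability, using PAMPA, with a stated time of 30 min, at pH 7.4 (a lower number here means that the compound crosses the layer more slowly, a higher number that the compound crosses the layer faster), stand as follows:
- Compound 1 `CC(C)Cc1ccc2c(NCCCNCc3ccco3)ccnc2c1` gives 23 10^-6 cm/s
- Compound 2 `c1ccc(CCc2ccc3c(NCCCNCc4ccco4)ccnc3c2)cc1` gives 23 10^-6 cm/s
- Compound 3 `COc1cccc(Oc2ccc3c(NCCCNCc4ccco4)ccnc3c2)c1` gives 317 10^-6 cm/s

Compound 3 has the highest number of the three, well clear of the other two. Compound 4 `Fc1ccc(Oc2ccc3c(NCCCNCc4ccco4)ccnc3c2)cc1` differs from it only at one place, with 4-fluorophenyl in place of 3-methoxyphenyl on an oxygen on an aromatic ring. Two large measured steps lead to compound 3 (a 14-fold higher number from compound 1 to compound 3 (1.14 log units; beyond the scatter) and a 14-fold higher number from compound 2 to compound 3 (1.14 log units; beyond the scatter)), and each brought in the 3-methoxyphenoxy group. Going by the values given here, compound 4 keeps an aromatic ring on that oxygen, but no measured step swaps one such ring for another, so the guide is loose. In this assay no step beyond the scatter is expected (a 1.1-fold lower number from compound 3 to compound 4 (0.05 log units; within the scatter)). Compound 4 is estimated at 280 10^-6 cm/s (range 110 10^-6 cm/s to 600 10^-6 cm/s).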

Compound 4, apparent permeability: 317 10^-6 cm/s
For compound 4 the middle estimate is 1.1-fold (0.05 log units) below the measured one; measured number inside the range.
By their numbers in this assay, from the lowest: compounds 1 and 2 (each within the scatter of the next); then compounds 3 and 4 (each within the scatter of the next).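

In this assay, the ring on this oxygen can change from 3-methoxyphenyl to 4-fluorophenyl with no real effect (no change at the digits printed from compound 3 to compound 4 (within the scatter)), so the high number does not depend on the methoxy group. The large rise also appears with this second phenoxy group (a 14-fold higher number from compound 2 to compound 4 (1.14 log units; beyond the scatter); a 14-fold higher number from compound 1 to compound 4 (1.14 log units; beyond the scatter)), and so is shared by 3-methoxyphenoxy and 4-fluorophenoxy. Nothing available explains why these two groups give the same high number.

Still open, going by these compounds, is whether a pyridine ring, or a phenyl ring carrying an amine or a carboxylic acid, would keep the number this high in place of 4-fluorophenyl.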